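Moving the Hydroxyl Outward Along a Fatty Acid Chain

A few compounds are considered here, and "the series" means these few. Any claim that something is new, unique, unknown or untested is made for them only; others in the source may bear on it.

Compound 1 `CCCC(O)CCCCCCCC(=O)O` and compound 2 `CCC(O)CCCCCCCCC(=O)O` are hydroxylated fatty acids that differ only in where the hydroxyl sits on the chain. In a functional assay on cells for agonist activity at Free fatty acid receptor 1 (Homo sapiens), read by BRET and beta-arrestin recruitment, with a stated time of 15 min (on this read-out higher numbers stand for an effect only at larger amounts of compound and lower numbers for an effect already at smaller amounts), compound 1 gives > 100000 nM, which is a limit of the assay rather than a number. In this assay compound 2 likewise gives > 100000 nM, again a limit. The step that the two limits leave unreadable from compound 1 to compound 2 therefore cannot be read from the two results. The evidence on measured steps amounts to the limit of > 100000 nM in this assay, at which 2 of the 2 values shown sit.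

Compound 3 `CC(O)CCCCCCCCCC(=O)O` continues the series. Relative to compound 2, the change is 2-hydroxypropyl in place of 1-hydroxypropyl on a saturated chain carbon, eight bonds along the chain from a carbonyl carbon. Among the compounds with values here, the only measured step, the one from compound 1 to compound 2, is unreadable, so there is no measured step that shows how this change moves the read-out in this assay. Compound 2 sits at a limit, and the step that the limit leaves unreadable from compound 2 to compound 3 is expected to be none beyond the scatter. The estimate for compound 3 in this assay is 150000 nM, with a range from 30000 nM to 1000000 nM, and the result is expected most likely to be reported once more only as a limit.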

Compound 3, half-maximal effective concentration: > 100000 nM
Compound 3: no number, only a limit; the forecaster's own chance of this, stated with the estimate: 85%; the middle value lies beyond the limit too.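

Compound 3 also gives only a limit in this assay, so none of the steps among compound 1, compound 2 and compound 3 can be read, and the results come down to one line: the limit of > 100000 nM in this assay, at which 3 of the 3 values shown sit.

The compounds shown leave open whether moving the hydroxyl along the chain changes the read-out at all.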